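The source may report more compounds than this note shows. Statements on the series, on what has been measured and on what is new or still open speak of the compounds shown alone.

Measured in a functional assay on HepG2 cells (Homo sapiens) for antiproliferative activity, read by MTT assay, with a stated time of 48 h; a lower number here means a stronger inhibitor, a higher number a weaker inhibitor:
Compound 1 `COc1ccc(Oc2nc3ccccc3cc2/C=N/NC(=O)Cn2c([N+](=O)[O-])cnc2C)cc1`: 4130 nM
Compound 2 `Cc1ncc([N+](=O)[O-])n1CC(=O)N/N=C/c1cc2ccccc2nc1Oc1ccc(Cl)cc1`: 220 nM
Compound 3 `Cc1ccc(Oc2nc3ccc(C)cc3cc2/C=N/NC(=O)Cn2c([N+](=O)[O-])cnc2C)cc1`: 21900 nM

Among the measured compounds shown here, compound 2 holds the lowest number of the three, and so is the strongest inhibitor measured in this assay so far. The next compound to be considered is compound 4 `Cc1ccc2nc(Oc3ccc(Cl)cc3)c(/C=N/NC(=O)Cn3c([N+](=O)[O-])cnc3C)cc2c1`, which departs from compound 2 by a single change: methyl in place of hydrogen on an aromatic carbon.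

For the measured compounds named here, no measured step isolates this change. Going by the values given here, the one measured step, a 19-fold lower number from compound 1 to compound 2 (1.27 log units; beyond the scatter), is a large one, but it concerns chloro in place of methoxy at another part of the molecule. Among the compounds with values here, it shows only that a single change can move the number a long way in this set. Compound 3 carries the methyl on the core and gives 21900 nM, a far weaker result than that of compound 2, which gives 220 nM. However, compound 3 also differs from compound 2 in a second place, so the data cannot divide that gap between the two changes.

A moderate move toward a weaker inhibitor is therefore expected, though with wide uncertainty. The estimated change is a 3.2-fold higher number from compound 2 to compound 4 (0.50 log units; beyond the scatter). For compound 4 the expected value is 700 nM, with an estimated range of 120 nM to 6000 nM.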

Compound 4, half-maximal inhibitory concentration: 3180 nM
Beside the measured number, compound 4's estimate is 4.5-fold (0.66 log units) below it; the range from low to high includes it.
By their numbers in this assay, from the lowest: compound 2; then compounds 4 and 1 (each within the scatter of the next); then compound 3.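

In this assay, among the compounds shown here, the step of a 14-fold higher number from compound 2 to compound 4 (1.16 log units; beyond the scatter) gives the first direct reading of this position: methyl in place of hydrogen on this aromatic carbon of the fused system is a large change toward a weaker inhibitor, so this carbon does not tolerate the added methyl without loss in this pair. The step of a 6.9-fold lower number from compound 3 to compound 4 (0.84 log units; beyond the scatter) shows that, with the core methyl in place, chloro in place of methyl still lowers the number beyond the scatter, and together the two steps divide the gap between compound 2 and compound 3, which could not be split before, into two real contributions. Nothing at hand accounts for either step.

The compounds shown hold only hydrogen or methyl at this carbon, so they leave open how a fluoro, a methoxy or an amine there would read. They also leave open whether the methyl step would keep its size with methoxy in place of the chloro, as the hydrogen-to-methyl change is seen directly in this one pair alone.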